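Nitrile for hydroxymethyl on the aryl group: compound 3 to compound 4

The compounds below may be only part of what the source reports. "The series", "measured", "known", "first", "only" and "open" are said of these compounds alone.

Measured so far in a functional assay on MIA PaCa-2 cells (Homo sapiens) for inhibition, read by MTT assay, with a stated time of 72 h, tested at 30 uM; a higher number here means more inhibition of growth at the concentration tested, a lower number less inhibition of growth:
- compound 1 `C=CCc1ccc(OCc2cn(-c3cccc([N+](=O)[O-])c3)nn2)c(O)c1`: 42.9%
- compound 2 `C=CCc1ccc(OCc2cn(-c3ccc(C#N)cc3)nn2)c(O)c1`: 39.3%
- compound 3 `C=CCc1ccc(OCc2cn(-c3ccccc3CO)nn2)c(O)c1`: 39.6%

All three values lie within the scatter of one another, so compound 3 holds no distinct rank in this small set. It sits with compound 2 and compound 1, and no order can be drawn among them.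

Next is compound 4 `C=CCc1ccc(OCc2cn(-c3cccc(C#N)c3)nn2)c(O)c1`, with 3-cyanophenyl in place of 2-(hydroxymethyl)phenyl on an aromatic nitrogen. The closest measured evidence is a number 0.3 percentage points higher from compound 2 to compound 3 (within the scatter), where compound 2 carries 4-cyanophenyl and compound 3 carries 2-(hydroxymethyl)phenyl. That step exchanges the same leaving group for a cyanophenyl group, and it stays within the scatter. Compound 1, with a different group at this place, gives 42.9%, also within the scatter of compound 3. The set is small, and none of its measured changes at this place moved the value beyond the scatter.

No step beyond the scatter is therefore expected, and the estimate is a number 0.4 percentage points higher from compound 3 to compound 4 (within the scatter). For compound 4 the expected value is 40%, with an estimated range from 32% to 49%.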

Compound 4, percent growth inhibition at one concentration: 26.6%
The estimate for compound 4 lay 13.4 percentage points above the measured number; the measured number lies below the stated range.
By their numbers in this assay, from the lowest: compound 4; then compounds 2, 3 and 1 (each within the scatter of the next).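

In this assay, this place on the aromatic nitrogen now shows its first steps beyond the scatter, and the identity of the group alone does not account for them: 3-cyanophenyl in place of 2-(hydroxymethyl)phenyl gives the first (a number 13 percentage points lower from compound 3 to compound 4 (beyond the scatter)), while 3-cyanophenyl in place of 4-cyanophenyl gives a step of similar size (a number 12.7 percentage points lower from compound 2 to compound 4 (beyond the scatter)), so two aryl groups that both carry a nitrile are separated here. Cyano in place of nitro on an aromatic carbon also gives a step beyond the scatter (a number 16.3 percentage points lower from compound 1 to compound 4 (beyond the scatter)), which leaves compound 4 apart from compounds 1, 2 and 3, and those three remain within the scatter of one another. The data shown offer no measurement that accounts for the lower number of compound 4.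

Among the compounds shown here, whether the lower number belongs to the nitrile in this placement alone stays open, since compound 4 is the only member of the set that stands apart. On these data alone, how an amine or a carboxylic acid on the aryl group would read in this assay also stays open, as does any ranking beyond this single tested concentration.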